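The compounds below may be only part of what the source reports. "The series", "measured", "known", "first", "only" and "open" are said of these compounds alone.

Measured in an ADME assay on microsomes from liver (Mus musculus) for metabolic stability, read by LC-MS, using NADPH, with a stated time of 60 min, tested at 1 uM; a higher number here means that the compound lasts longer, a lower number that the compound disappears faster:
- compound 1 `O=C(O)CCC1Cc2ccc(-c3cc(F)cc(OC(F)F)c3)cc2N1S(=O)(=O)c1cccc(C(F)(F)F)c1` gives 1.02 h
- compound 2 `O=C(O)CCCC1Cc2ccc(-c3cc(F)cc(OC(F)F)c3)cc2N1S(=O)(=O)c1cccc(C(F)(F)F)c1` gives 1.56 h
- compound 3 `O=C(CC1Cc2ccc(-c3cc(F)cc(OC(F)F)c3)cc2N1S(=O)(=O)c1cccc(C(F)(F)F)c1)N1CC2(COC2)C1` gives 0.0117 h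

Compound 3 stands lowest of the three. Compound 4 `O=C(O)C1CCN(C(=O)CC2Cc3ccc(-c4cc(F)cc(OC(F)F)c4)cc3N2S(=O)(=O)c2cccc(C(F)(F)F)c2)CC1` differs from it by a group of 9 heavy atoms (6 carbon, 1 nitrogen, 2 oxygen; one six-membered non-aromatic ring with 1 hetero atom) in place of a group of 7 heavy atoms (5 carbon, 1 nitrogen, 1 oxygen; 2 four-membered non-aromatic rings with 1 hetero atom each), on a carbonyl carbon. The carbonyl stays, and the entering 4-carboxypiperidin-1-yl carries a carboxy group, as compounds 1 and 2 do.

For the measured compounds named here, two measured steps bear on this: an 87-fold lower number from compound 1 to compound 3 (1.94 log units; beyond the scatter) and a 130-fold lower number from compound 2 to compound 3 (2.12 log units; beyond the scatter). Both were large. a 1.5-fold higher number from compound 1 to compound 2 (0.18 log units; within the scatter) shows little dependence on chain length. Going by the values given here, no measured compound combines the carbonyl amide with a carboxy group, so only a partial return in this assay is expected. The expected step is a 34-fold higher number from compound 3 to compound 4 (1.53 log units; beyond the scatter). For compound 4 the estimate is 0.4 h, with an expected range from 0.06 h to 1.6 h.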

Compound 4, half-life: 0.502 h
For compound 4 the middle estimate is 1.3-fold (0.10 log units) below the measured one, within the range that was stated.
By their numbers in this assay, from the lowest: compound 3; then compound 4; then compounds 1 and 2 (each within the scatter of the next).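

On the carbonyl carbon in this assay, 4-carboxypiperidin-1-yl in place of the group with two four-membered rings gives a large rise (a 43-fold higher number from compound 3 to compound 4 (1.63 log units; beyond the scatter)), so an amide carbonyl at this position need not bring a number as low as that of compound 3. The return is incomplete, though modest, with both (a 2.0-fold lower number from compound 1 to compound 4 (0.31 log units; beyond the scatter)) and (a 3.1-fold lower number from compound 2 to compound 4 (0.49 log units; beyond the scatter)) beyond the scatter. No measurement shown explains these steps.

Open, going by these compounds, is whether the rise follows the carboxy group or the six-membered ring. A plain piperidin-1-yl on the same carbonyl carbon would separate the two.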